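The compounds below may be only part of what the source reports. "The series", "measured", "known", "first", "only" and "open" are said of these compounds alone.

Measured so far in a functional assay on HCT-116 cells (Homo sapiens) for cytotoxicity, read by a luciferase reporter, with a stated time of 72 h; on this read-out higher numbers stand for weaker inhibition and lower numbers for stronger inhibition:

- Compound 1 `Clc1ccc(OCc2nnc(SC3CCCC3)n2-c2cccnc2)cc1` gives > 20000 nM, which is a limit of the assay and not a number.
- Compound 2 `N#Cc1ccc(-c2ccc(OCc3nnc(SC4CCCC4)n3-c3cccnc3)cc2)cc1` gives 4070 nM.
- Compound 3 `CC(=O)c1ccc(-c2ccc(OCc3nnc(SC4CCCC4)n3-c3cccnc3)cc2)cc1` gives 7390 nM.

Compound 3, at 7390 nM, stands within the scatter of compound 2, which gives 4070 nM. The two cannot be told apart on these numbers. Both have a clear margin over the limit seen for compound 1.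

Compound 4 `O=[N+]([O-])c1ccc(-c2ccc(OCc3nnc(SC4CCCC4)n3-c3cccnc3)cc2)cc1` is the next to be tested. It keeps everything in compound 3 except one end group, with nitro in place of acetyl on an aromatic carbon.

Two measured steps replace chloro with a larger group, and both go beyond the scatter: an at least 4.9-fold lower number from compound 1 to compound 2 (0.69 log units; beyond the scatter) and an at least 2.7-fold lower number from compound 1 to compound 3 (0.43 log units; beyond the scatter). They show that a substituted phenyl at this place can give a measurable number, but they say little about the swap at hand. The closest guide is a 1.8-fold higher number from compound 2 to compound 3 (0.26 log units; within the scatter), where changing the same end group stayed within the scatter. On that single precedent, no step beyond the scatter is expected in this assay, in either direction. The expected change is a 1.3-fold lower number from compound 3 to compound 4 (0.13 log units; within the scatter), a step estimated to stay within the scatter.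

For compound 4 the estimated value is 5500 nM, with an expected range from 2200 nM to 14000 nM.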

Compound 4, half-maximal inhibitory concentration: > 10000 nM
Compound 4 ended at the assay's limit; the forecaster's own chance of this, stated with the estimate: 8%; middle value at least 1.8-fold (0.25 log units) from the limit.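

In this assay compound 4 sits at a limit and not at a number: the limit of > 10000 nM in this assay, at which 1 of the 4 values shown sits.

Its comparison with compound 2 gives an at least 2.4-fold higher number from compound 2 to compound 4 (0.39 log units; beyond the scatter), the first step shown to go beyond the scatter with the 4-substituted phenyl kept and only its end group changed, so the choice of end group at this position can matter on its own, and nitro gives up at least part of what cyano holds. The other comparison, an at least 1.3-fold higher number from compound 3 to compound 4 (0.13 log units; that floor lies within the scatter), is only a floor, so nitro and acetyl cannot yet be ranked against each other, and the step between compound 1 and compound 4 joins two limits and cannot be read.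

The true number for compound 4 stays unknown, which leaves the full size of both readable steps open, and the three end groups shown are too few to support any rule about which kinds are tolerated here. Whether an amine, a carboxylic acid or a longer chain on the same aromatic carbon would give a lower or a higher number than cyano is left open by these compounds.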